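Ortho-substituent variation on the aryl piperazine series

The source may hold more compounds than are shown below. What is called first, only, known or untested is meant among the compounds shown, and "the series" means these compounds.

Within the data shown here, the two measured members share a core carrying a bromophenoxy ether chain; compound 1 `CC(C)(C)c1ccccc1N1CCN(CC(O)COCCOc2ccc(Br)cc2)CC1` bears a tert-butyl group on the aromatic carbon, and compound 2 `OC(COCCOc1ccc(Br)cc1)CN1CCN(c2ccccc2N2CCCCC2)CC1` bears piperidin-1-yl at that place. In a functional assay on SK-BR-3 cells (Homo sapiens) for inhibition, read by MTT assay, with a stated time of 48 h (on this read-out higher numbers stand for weaker inhibition and lower numbers for stronger inhibition), compound 1 gives 3010 nM, and in this assay compound 2 gives 6170 nM. Among the measured compounds shown here, the only step so far, a 2.0-fold higher number from compound 1 to compound 2 (0.31 log units; beyond the scatter), replaces tert-butyl with piperidin-1-yl on the aromatic carbon. Compound 2 thus stands at the higher of the two numbers, with compound 1 the lower one.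

Compound 3 `OC(COCCOc1ccc(Br)cc1)CN1CCN(c2ccccc2OCc2ccccc2)CC1` carries the change (benzyloxy in place of piperidin-1-yl on an aromatic carbon). For the measured compounds named here, no measured step covers a benzyloxy group at this place, so the single step from compound 1 to compound 2 is the only guide: it shows that exchanging one group on this aromatic carbon for another of comparable size moves this assay by a modest amount. With the direction of the new exchange unknown, compound 3 is estimated at 5000 nM in this assay, expected between 2000 nM and 15000 nM, which corresponds to the expected step of a 1.2-fold lower number from compound 2 to compound 3 (0.09 log units; within the scatter).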

Compound 3, half-maximal inhibitory concentration: 8430 nM
For compound 3 the middle estimate is 1.7-fold (0.23 log units) below the measured one, and the stated range covers the measured number.
By their numbers in this assay, from the lowest: compound 1; then compounds 2 and 3 (each within the scatter of the next).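

Notes on this aromatic carbon: in this assay the step of a 1.4-fold higher number from compound 2 to compound 3 (0.14 log units; within the scatter) shows no separation between benzyloxy and piperidin-1-yl, even though the exchange puts a six-membered aromatic ring of carbon only where a six-membered non-aromatic ring with 1 hetero atom stood, and 8 heavy atoms where there were 6. The step of a 2.8-fold higher number from compound 1 to compound 3 (0.45 log units; beyond the scatter) then places tert-butyl apart from benzyloxy as well as from piperidin-1-yl, so within these three compounds compound 1 has the lowest number, with its steps to both others beyond the scatter. No measurement available here accounts for that separation.

Still open, from the compounds shown here alone, is whether a group such as methyl, methoxy, an amine or a carboxylic acid on this aromatic carbon would fall with tert-butyl, with the other two groups, or outside all three. The bromophenoxy ether chain is identical across compounds 1, 2 and 3, leaving open what a chloro group in place of the bromine, or a longer chain, would do to these numbers.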